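A few compounds are considered here, and "the series" means these few. Any claim that something is new, unique, unknown or untested is made for them only; others in the source may bear on it.

Series notes. Compound 1 `O=C(/C=C/c1ccc(OCCCCCO[N+](=O)[O-])c(O)c1)OCCCCCO[N+](=O)[O-]` carries a nitrate on both chains. In a functional assay on Calu-1 cells (Homo sapiens) for cytotoxicity, read by resazurin assay, with a stated time of 72 h (on this read-out higher numbers stand for weaker inhibition and lower numbers for stronger inhibition), compound 1 reaches only a limit, > 50000 nM, and gives no number; this is the limit of > 50000 nM in this assay, at which 1 of the 3 values shown sits. Compound 2 `O=C(/C=C/c1ccc(O)c(O)c1)OCc1c(-c2ccccc2)no[n+]1[O-]` gives 7680 nM in this assay. Compound 3 `COc1cc(/C=C/C(=O)OC/C=C/CO[N+](=O)[O-])ccc1O` gives 2480 nM in this assay, the lowest of the two numbers obtained; the nearest number, that of compound 2, sits higher by a margin beyond the scatter. No pair among these three differs in one place only, so no measured step is available in the series.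

Compound 4 `COc1cc(/C=C/C(=O)OCCCO[N+](=O)[O-])ccc1O` has not been measured. It differs from compound 3 in one place: a group of 6 heavy atoms (2 carbon, 1 nitrogen, 3 oxygen; no ring) in place of a group of 7 heavy atoms (3 carbon, 1 nitrogen, 3 oxygen; no ring), on a saturated chain carbon bound to an oxygen next to a carbonyl group. The change takes away one of the double bonds outside aromatic rings and leaves the nitrate in place. Going by the values given here, with no measured step of this kind to lean on, the expectation in this assay is a change of no more than the scatter, in either direction. Compound 4 is therefore expected to give about 3000 nM, with a range from 1200 nM to 8000 nM. The step of a 1.2-fold higher number from compound 3 to compound 4 (0.08 log units; within the scatter) is expected to stay within the scatter.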

Compound 4, half-maximal inhibitory concentration: > 50000 nM
Compound 4: no number, only a limit; the forecaster's own chance of this, stated with the estimate: 5%; at least 16-fold (1.22 log units) between middle value and limit.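

At the saturated chain carbon bound to an oxygen next to a carbonyl group, this small change is far from neutral in this assay: the 2-(nitrooxy)ethyl group in place of the larger group gives an at least 20-fold higher number from compound 3 to compound 4 (1.30 log units; beyond the scatter). Both compounds keep the nitrate, so its presence alone does not preserve the read-out in this pair. Compound 4 gives only a limit, and this limit recurs in the series: the limit of > 50000 nM in this assay, at which 2 of the 4 values shown sit.

The change removes a double bond outside aromatic rings and shortens the group at once, so the compounds shown do not tell which of the two matters. On these data alone, how a longer saturated chain carrying the nitrate, or an amine in place of the nitrate, would read in this assay also remains open.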